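This account rests on a few compounds, and the source may have more. Where it says the series, first, only, none or still open, it means among the compounds named here.

Compound 1 `O=C(Nc1ccc(Br)cc1CN1C(=O)c2ccccc2C1=O)c1ccccn1`, compound 2 `O=C(Nc1ccc(Cl)cc1CN1C(=O)c2ccccc2C1=O)c1cccnc1` and compound 3 `O=C(Nc1ccc(Cl)cc1CN1C(=O)c2ccccc2C1=O)c1ccco1` share one core and differ only in the aromatic ring that sits on a carbonyl carbon, and in one substituent on the shared core. In an assay on CHO cells for positive allosteric modulation of metabotropic glutamate receptor 5 (Rattus norvegicus), read by FLIPR (on this read-out lower numbers stand for an effect already at smaller amounts and higher numbers for an effect only at larger amounts of compound), compound 1 gives < 1000 nM, which is a limit of the assay rather than a number. In this assay compound 2 gives < 1000 nM, again a limit. In this assay compound 3 gives < 1000 nM, also a limit. Compound 3 thus stands where every value here stands, at the limit of < 1000 nM in this assay, at which 3 of the 3 values shown sit, and no order among the three compounds can be read. The one-place step that the two limits leave unreadable from compound 2 to compound 3 accordingly has no readable size. Compound 4 `O=C(Nc1ccc(Cl)cc1CN1C(=O)c2ccccc2C1=O)c1cncs1` is compound 3 with 1,3-thiazol-5-yl in place of furan-2-yl on a carbonyl carbon. Within the data shown here, no measured step bears on this change in a readable way, since the nearest comparison, furan-2-yl for pyridin-3-yl, is hidden behind the limits. Compound 4 is therefore expected to sit near the others, with an estimated 300 nM and a range from 40 nM to 2500 nM. This estimate means a step that the limit leaves unreadable from compound 3 to compound 4, a step expected to stay within the scatter.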

Compound 4, half-maximal effective concentration: < 1000 nM
Compound 4: a limit, no number; the forecaster's own chance of this, stated with the estimate: 60%; the middle value lies beyond the limit too.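

Compound 4 ends up, like compound 2 and compound 3, at a limit rather than a number, so no step among these compounds can be read: the limit of < 1000 nM in this assay, at which 4 of the 4 values shown sit.

As far as these compounds go, whether 1,3-thiazol-5-yl, furan-2-yl and pyridin-3-yl on a carbonyl carbon differ at all in this assay stays open.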